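Adding a Methyl to the Ring Nitrogen of Compound 2

The source may report more compounds than this note shows. Statements on the series, on what has been measured and on what is new or still open speak of the compounds shown alone.

Compound 1, `O=C1/C(=C/c2cccnc2)CNC/C1=C\c1cccnc1`: 11100 nM in a functional assay on A549 cells (Homo sapiens) for cytotoxicity, read by MTT assay, with a stated time of 72 h; on this read-out higher numbers stand for weaker inhibition and lower numbers for stronger inhibition
Compound 2, `O=C1/C(=C/c2ccncc2)CNC/C1=C\c1ccncc1`: 10300 nM in this assay

Both compounds share the same core and differ only in how the pyridine rings are attached. Compound 2 gives the lower of the two numbers in this assay, but the gap to compound 1 lies within the scatter of repeated measurements, so the two cannot be told apart.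

Compound 3, `CN1C/C(=C\c2ccncc2)C(=O)/C(=C/c2ccncc2)C1`, is not yet measured. It differs from compound 2 by methyl in place of hydrogen on an amine nitrogen in a ring. No comparable change has been measured in this set, so nothing shows how the ring nitrogen affects potency. Such a small addition is expected to give no step beyond the scatter, perhaps a slight shift toward stronger inhibition, so the step of a 1.3-fold lower number from compound 2 to compound 3 (0.11 log units; within the scatter) is an estimate only. Compound 3 is expected to give 8000 nM in this assay, within 3000 nM to 25000 nM.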

Compound 3, half-maximal inhibitory concentration: 4200 nM
For compound 3 the middle estimate is 1.9-fold (0.28 log units) above the measured one; measured number inside the range.
By their numbers in this assay, from the lowest: compound 3; then compounds 2 and 1 (each within the scatter of the next).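

Methylating the ring nitrogen of compound 2 produces the first change in this set that can be told apart from assay noise: in this assay, the step (a 2.5-fold lower number from compound 2 to compound 3 (0.39 log units; beyond the scatter)) is modest but real. Compounds 1 and 2 could not be separated, so they gave no sign that the shared core responds to any change in its structure; compound 3 shows that this amine nitrogen in a ring is a place where even a single added carbon shifts the read-out. No available evidence accounts for the shift.

The compounds shown leave open whether an ethyl group, a longer chain or an acetyl group on this nitrogen would lower the number further or raise it again. They also leave open whether a methyl on the same nitrogen of compound 1 would give a similar step.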